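Working notes: from compound 2 to compound 3

A few compounds are considered here, and "the series" means these few. Any claim that something is new, unique, unknown or untested is made for them only; others in the source may bear on it.

In a functional assay on A549 cells (Homo sapiens) for antiproliferative activity, read by MTT assay, with a stated time of 72 h (on this read-out higher numbers stand for weaker inhibition and lower numbers for stronger inhibition), compound 1 `O=C(N/N=C/c1ccccc1)Nc1ccc(Oc2ccnc3[nH]ccc23)c(F)c1` gives 2500 nM as its value. Compound 2 `O=C(N/N=C/c1cccc([N+](=O)[O-])c1)Nc1ccc(Oc2ccnc3[nH]ccc23)c(F)c1` gives 3640 nM on the same read-out, which places it within the scatter of compound 1, so the two cannot be ranked. The next change leads to compound 3 `O=C(N/N=C/c1ccc(F)cc1Cl)Nc1ccc(Oc2ccnc3[nH]ccc23)c(F)c1` and is counted as 2-chloro-4-fluorophenyl in place of 3-nitrophenyl on a carbon with a double bond to nitrogen and amounts to 2-chloro-4-fluorophenyl in place of 3-nitrophenyl on a carbon with a double bond to nitrogen. Among the measured compounds shown here, only one measured step bears on this, namely a 1.5-fold higher number from compound 1 to compound 2 (0.16 log units; within the scatter) for nitro in place of hydrogen on an aromatic carbon. For the measured compounds named here, no measured compound carries a halogen on that ring, so the evidence is thin. No step beyond the scatter is expected in this assay because a 1.5-fold higher number from compound 1 to compound 2 (0.16 log units; within the scatter) stayed within it, and no direction is favoured. The expected step is a 1.2-fold lower number from compound 2 to compound 3 (0.08 log units; within the scatter) and it would remain within the scatter. For compound 3 the estimated value is 3000 nM with an expected range from 1000 nM to 9000 nM on this read-out.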

Compound 3, half-maximal inhibitory concentration: 10 nM
Estimate against measurement, compound 3: 300-fold (2.48 log units) above; the whole stated range lies above it.
By their numbers in this assay, from the lowest: compound 3; then compounds 1 and 2 (each within the scatter of the next).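

In this assay the aryl group on the carbon with a double bond to nitrogen proves able to shift the read-out strongly: 2-chloro-4-fluorophenyl in place of 3-nitrophenyl gives a 360-fold lower number from compound 2 to compound 3 (2.56 log units; beyond the scatter) and 2-chloro-4-fluorophenyl in place of phenyl gives a 250-fold lower number from compound 1 to compound 3 (2.40 log units; beyond the scatter) while the earlier nitro-for-hydrogen change stayed within the scatter. This position is therefore not indifferent to what it carries, which compound 1 and compound 2 alone could not show, and both large steps run in the same direction from two starting compounds that cannot be ranked against each other. Nothing measured here accounts for the size of these steps.

The 2-chloro-4-fluorophenyl group enters as a whole, so the compounds shown leave open whether the chlorine alone or the fluorine alone would give a comparable step, or whether the two are needed together. Also open, from the compounds shown here alone, is how this position would respond to an amine, a methoxy group or a carboxylic acid on the ring, or to a second halogen pattern on the same phenyl ring.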